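The source may report more compounds than this note shows. Statements on the series, on what has been measured and on what is new or still open speak of the compounds shown alone.

Values in an ADME assay on MDBK cells (Bos taurus) for cytotoxicity, read by MTT assay, with a stated time of 96 h (a higher number here means that more compound is tolerated, a lower number that less compound is tolerated), each one a limit of the assay:

- Compound 1 `C/C(=N\NC(N)=S)c1ccc2[nH]c(-c3ccc(Cl)cc3)nc2c1`: > 100000 nM
- Compound 2 `CC(=O)c1ccc2c(c1)nc(-c1ccc(Cl)cc1)n2C1CCCCC1`: > 100000 nM
- Compound 3 `C/C(=N\NC(N)=S)c1ccc2c(c1)nc(-c1ccc(Cl)cc1)n2C1CCCCC1`: > 100000 nM

Within the data shown here, no measured compound has yet given an exact number: the limit of > 100000 nM in this assay, at which 3 of the 3 values shown sit. Compound 4 `C/C(=N\NC(N)=S)c1ccc2c(c1)nc(-c1ccccn1)n2C1CCCCC1` has pyridin-2-yl in place of 4-chlorophenyl on an aromatic carbon. Two measured steps lead to compound 3, but both change other places: a step that the two limits leave unreadable from compound 1 to compound 3 and a step that the two limits leave unreadable from compound 2 to compound 3. Neither gives a size to carry over, so no change beyond the usual scatter is expected in this assay. The expected step is a number no higher from compound 3 to compound 4 (the limit leaves the size open). The estimate for compound 4 is 100000 nM, with an expected range of 40000 nM to 200000 nM.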

Compound 4, half-maximal cytotoxic concentration: 41000 nM
Compound 4: middle estimate off by 2.4-fold (0.39 log units), on the high side; the range from low to high includes it.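

In this assay, pyridin-2-yl in place of 4-chlorophenyl on this aromatic carbon gives the first exact number, a change described as an at least 2.4-fold lower number from compound 3 to compound 4 (0.38 log units; beyond the scatter). A change at this position alone can therefore shift the tolerated concentration beyond the usual scatter. The full size of the step stays unknown, because compound 3 gives only a limit: the limit of > 100000 nM in this assay, at which 3 of the 4 values shown sit.

The compounds shown leave open whether the ring nitrogen or the loss of chlorine matters more, which plain phenyl would help separate. Going by these compounds, how an amine at this position would behave also remains open.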